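This account rests on a few compounds, and the source may have more. Where it says the series, first, only, none or still open, it means among the compounds named here.

Compound 1 `COc1cc(OC2CCC2)nc(-c2ccc3c(c2)CC[C@H](CCC(=O)O)O3)c1F` is the starting point of this note. In a functional assay on HEK293 cells for agonist activity at Free fatty acid receptor 1 (Homo sapiens), read by HTRF and inositol phosphate accumulation, with a stated time of 60 min (a higher number here means that more compound is needed for the effect, a lower number that less compound is needed), compound 1 returns only a limit of the assay, > 10000 nM. Compound 2 `COc1cc(O[C@H]2C[C@H](OC)C2)nc(-c2ccc3c(c2)CC[C@H](CCC(=O)O)O3)c1F` carries a methoxy in place of hydrogen on a saturated ring carbon. In this assay compound 2 also returns only a limit, > 10000 nM. The step that the two limits leave unreadable from compound 1 to compound 2 thus cannot be sized, since both values rest at the limit of > 10000 nM in this assay, at which 2 of the 2 values shown sit. Compound 3 `O=C(O)CC[C@H]1CCc2cc(-c3nc(OC4CCC4)ccc3F)ccc2O1` differs from compound 1 by hydrogen in place of methoxy on an aromatic carbon. Going by the values given here, no measured step touches that aromatic position, and the single measured step is unreadable, so the data give no ground to expect a move beyond scatter in either direction. For compound 3 the expected value in this assay is 10000 nM, with a range from 2000 nM to 50000 nM. The expected step of a number no higher from compound 1 to compound 3 (the limit leaves the size open) is accordingly flat, with a real chance that compound 3 again reports only a limit.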

Compound 3, half-maximal effective concentration: > 10000 nM
Compound 3: a limit, no number; the forecaster's own chance of this, stated with the estimate: 70%; the middle value sits exactly at the limit.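

Going by these compounds alone, compound 3 gives > 10000 nM, again a limit and not a number, so no step from compound 1 to compound 3 can be read: the limit of > 10000 nM in this assay, at which 3 of the 3 values shown sit. The compounds shown leave open how far each lies from that limit, and so whether either methoxy change shifts the value at all.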